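Chloro for fluoro on a sulfonyl-bearing compound

The source may report more compounds than this note shows. Statements on the series, on what has been measured and on what is new or still open speak of the compounds shown alone.

In an ADME assay on cells (Hepatocyte, Mus musculus) for cytotoxicity, read by MTT assay, with a stated time of 24 h (on this read-out higher numbers stand for lower toxicity in this test and lower numbers for higher toxicity in this test), compound 1 `Cc1ccc(-c2nn(-c3ccccc3)cc2-c2nc3ccccc3[nH]2)cc1` gives > 300000 nM, which is a limit of the assay and not a number. Compound 2 `Cc1ccc(-c2nn(-c3ccccc3)cc2-c2nc3ccccc3n2S(=O)(=O)c2ccc(C)cc2)cc1` gives 102000 nM. Among the measured compounds shown here, compound 3 `Cc1ccc(-c2nn(-c3ccccc3)cc2-c2nc3ccccc3n2S(=O)(=O)c2ccc(F)cc2)cc1` gives 167000 nM, within the scatter of compound 2, the only other exact number.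

Compound 4 `Cc1ccc(-c2nn(-c3ccccc3)cc2-c2nc3ccccc3n2S(=O)(=O)c2ccc(Cl)cc2)cc1` carries chloro in place of fluoro on an aromatic carbon, para to a large group: chloro in place of fluoro on an aromatic carbon. The closest measured change swapped methyl for fluoro on an aromatic carbon, a 1.6-fold higher number from compound 2 to compound 3 (0.21 log units; within the scatter). Adding the whole sulfonyl group is a different kind of change, seen in an at least 2.9-fold lower number from compound 1 to compound 2 (0.46 log units; beyond the scatter) and an at least 1.7-fold lower number from compound 1 to compound 3 (0.25 log units; that floor lies within the scatter). The expected size is a 1.3-fold lower number from compound 3 to compound 4 (0.11 log units; within the scatter), so no step beyond the scatter is expected. For compound 4 the estimated value is 130000 nM, within an expected range of 70000 nM to 240000 nM.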

Compound 4, half-maximal cytotoxic concentration: 216000 nM
Estimate against measurement, compound 4: 1.7-fold (0.22 log units) below, within the range that was stated.
By their numbers in this assay, from the lowest: compounds 2, 3 and 4 (each within the scatter of the next, the first and the last beyond it). At a limit, above all of these: compound 1.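

In this assay, chloro in place of fluoro gives a 1.3-fold higher number from compound 3 to compound 4 (0.11 log units; within the scatter), so this step stays within the scatter. Chloro in place of methyl gives a 2.1-fold higher number from compound 2 to compound 4 (0.33 log units; beyond the scatter), the first modest step among the sulfonyl-bearing compounds, pointing to slightly lower toxicity in this test. From the compounds shown here alone, compound 1 stands at > 300000 nM, a limit of the assay and not a number: the limit of > 300000 nM in this assay, at which 1 of the 4 values shown sits. Adding the (4-chlorophenyl)sulfonyl group gives an at least 1.3-fold lower number from compound 1 to compound 4 (0.14 log units; that floor lies within the scatter), so the true size of this step stays unknown.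

Open, going by these compounds, is how an amine or a carboxylic acid on the same aromatic carbon would compare.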